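Selenocyanate and diselenide carbamates: cytotoxicity notes

The source may hold more compounds than are shown below. What is called first, only, known or untested is meant among the compounds shown, and "the series" means these compounds.

Measured so far:
- compound 1, `COc1ccc(OC(=O)Nc2ccc([Se]C#N)cc2)cc1`: 70000 nM
- compound 2, `O=C(Nc1ccc([Se][Se]c2ccc(NC(=O)OCc3ccccc3)cc2)cc1)OCc1ccccc1`: 67900 nM
- compound 3, `CCCCOC(=O)Nc1ccc([Se][Se]c2ccc(NC(=O)OCCCC)cc2)cc1`: 72300 nM

The three compounds share an aryl carbamate unit and differ in the selenium-bearing group and in the carbamate ester. In a functional assay on CCRF-CEM cells (Homo sapiens) for cytotoxicity, read by MTT assay, with a stated time of 72 h (a lower number here means that less compound is tolerated, a higher number that more compound is tolerated), compound 1 gives 70000 nM. Compound 2 gives 67900 nM in this assay and compound 3 gives 72300 nM. On the numbers shown, compound 1 sits second highest of the three, but its gaps to compound 2 and to compound 3 both lie within the usual scatter, so no order among the three can be read from these values; the series so far is flat.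

The next compound, compound 4, `Cc1ccc(OC(=O)Nc2ccc([Se]C#N)cc2)cc1`, keeps the selenocyanate and the aryl carbamate of compound 1 and changes only the substituent on the ester ring: methyl in place of methoxy on an aromatic carbon.

Among the measured compounds shown here, no step between two measured compounds shows what such a change does here, so the expectation rests only on the flatness of the measured set. The step from compound 1 to compound 4 is expected to be small, no change at the digits printed from compound 1 to compound 4 (within the scatter), in no preferred direction and not beyond the scatter. Compound 4 is therefore estimated at 70000 nM in this assay, with a range from 30000 nM to 160000 nM.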

Compound 4, concentration lethal to 50% of the cells: 72000 nM
Compound 4: middle estimate off by 1.0-fold (0.01 log units), on the low side; the range from low to high includes it.
By their numbers in this assay, from the lowest: compounds 2, 1, 4 and 3 (each within the scatter of the next).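

In this assay, among the compounds shown here, the replacement of methoxy by methyl on an aromatic carbon, para to a large group, gives a 1.0-fold higher number from compound 1 to compound 4 (0.01 log units; within the scatter), and this is the first comparison between two compounds that differ in one place. At this position on the ester ring, the two groups cannot be told apart in this read-out, even though the oxygen of the methoxy and its hydrogen-bond acceptor leave with the change. The flatness seen earlier across compounds differing in several places therefore now also holds for one matched pair, though only for this pair and this change. No measurement accompanies the result that could explain why the two groups read alike.

Still open, from the compounds shown here alone, is whether a different group at this place, such as an amine, a carboxylic acid or a longer chain, would read apart from compound 1 and compound 4. Also open, going by these compounds, is whether the same replacement would read alike on a diselenide, as compound 2 and compound 3 differ from compound 1 and compound 4 in more than one place and give no matched comparison.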